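Replacing a Pyrrolidinyl Ester with an Anilide on the Core

The source may report more compounds than this note shows. Statements on the series, on what has been measured and on what is new or still open speak of the compounds shown alone.

This account concerns a small set of compounds sharing one core, all aimed at the same readout. Compound 1 `CN1CCN(c2ccc(Nc3ncc4nc(Nc5ccc(F)cc5)n(CCNS(=O)(=O)C5CC5)c4n3)cc2)CC1` stands at "not determined" (no result reported) in a functional assay on NCI-H1975 cells (Homo sapiens) for antiproliferative activity, read by MTT assay, with a stated time of 72 h (on this read-out lower numbers stand for stronger inhibition and higher numbers for weaker inhibition), and compound 3 `CCOC(=O)CN1CC[C@H](n2c(Nc3ccc(F)cc3)nc3cnc(Nc4ccc(N5CCN(C)CC5)cc4)nc32)C1` likewise stands at "not determined" (no result reported); neither was reported with a result. For the measured compounds named here, the only measured member is compound 2 `CN1CCN(c2ccc(Nc3ncc4nc(Nc5ccc(F)cc5)n([C@H]5CCCN(S(=O)(=O)C6CC6)C5)c4n3)cc2)CC1`, which in this assay gives 1150 nM. Compound 3 therefore stands without a value of its own, and its neighbour compound 1 stands in the same position, so nothing about compound 3 can be read from numbers.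

The step to compound 4 `CN1CCN(c2ccc(Nc3ncc4nc(Nc5ccc(F)cc5)n(-c5cccc(NC(=O)CO)c5)c4n3)cc2)CC1` changes the group on the aromatic nitrogen: 3-(((hydroxymethyl)carbonyl)amino)phenyl in place of 1-((ethoxycarbonyl)methyl)pyrrolidin-3-yl on an aromatic nitrogen. Going by the values given here, no measured step between two compounds that differ in one place exists in this set, so the size of this change cannot be calibrated against anything comparable. Among the compounds with values here, the sole anchor is compound 2, whose value in this assay is 1150 nM; the change itself is a swap of one substituent for another of equal size, as the difference itself records, and in this assay no shift beyond the usual scatter in either direction is expected from it on the evidence at hand.

Compound 4 is accordingly estimated to give about 900 nM in this assay, with a plausible range from 150 nM to 5000 nM.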

Compound 4, half-maximal inhibitory concentration: 580 nM
The estimate for compound 4 lay 1.6-fold (0.19 log units) above the measured number; the range from low to high includes it.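

For the compounds shown here, compound 4 gives the set a second number at this position, and in this assay the only step that can be read is a 2.0-fold lower number from compound 2 to compound 4 (0.30 log units; within the scatter), which places a 3-(((hydroxymethyl)carbonyl)amino)phenyl group, with its six-membered aromatic ring of carbon only, on the same aromatic nitrogen as the 1-(cyclopropylsulfonyl)piperidin-3-yl group and leaves the read-out within the usual scatter. The swap from the 1-((ethoxycarbonyl)methyl)pyrrolidin-3-yl group of compound 3 to the group of compound 4 cannot be read, as compound 3 has no number to set against that of compound 4, so the equal heavy-atom count of these two groups says nothing yet about their effect. No accompanying measurement bears on this result, and it stays a plain observation without an explanation.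

On these data alone, whether the aromatic ring or the hydroxyacetyl amide on it matters for the number remains open, as a plain phenyl group has no value to compare here. Equally open, as far as these compounds go, is how a phenyl ring carrying a carboxylic acid or a primary amine in place of that amide would read in this assay.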